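The source may report more compounds than this note shows. Statements on the series, on what has been measured and on what is new or still open speak of the compounds shown alone.

Compound 1 `CC1=C(C(=O)Nc2ccc(F)cc2)C(c2ccc([N+](=O)[O-])cc2)N=C(SCc2ccc(Cl)cc2)N1`: 28.2%
Compound 2 `COc1ccc(C2N=C(SCc3ccccc3)NC(C)=C2C(=O)Nc2ccc(Br)cc2)cc1`: 11.3%
Compound 3 `CC1=C(C(=O)Nc2ccc([N+](=O)[O-])cc2)C(c2ccc(Br)cc2)N=C(SCc2ccccc2)N1`: 27.2%

In a functional assay on the whole organism (artery, strain albino) with Rattus norvegicus as the target, with a stated time of 600 min, at a dose of 10 mg/kg by the oral route (on this read-out higher numbers stand for more inhibition at the one dose given (going by the name of the read-out) and lower numbers for less inhibition), compound 3 gives 27.2%, the second highest of these three numbers. Compound 1 sits within the usual scatter of it, while compound 2 lies beyond the scatter on the lower side. Compound 4 `CC1=C(C(=O)Nc2ccc([N+](=O)[O-])cc2)C(c2ccc(Br)cc2)N=C(SCc2ccc(F)cc2)N1` differs from compound 3 in one place only: fluoro in place of hydrogen on an aromatic carbon. Among the compounds with values here, no pair of measured compounds shows this change on its own, so its effect in this assay has not been seen directly. Compound 1 also carries a 4-fluorobenzyl group and its value stands close to that of compound 3, though it differs in other places too. A step from compound 3 to compound 4 of a number 0.8 percentage points higher from compound 3 to compound 4 (within the scatter) is expected, that is, none beyond the scatter. Compound 4 is therefore estimated at 28%, in the range 15% to 42%.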

Compound 4, a percentage reported as inhibition, in the whole organism at one dose (the size of the read-out at that dose, not a potency): 32.3%
Estimate against measurement, compound 4: 4.3 percentage points below, within the range that was stated.
By their numbers in this assay, from the lowest: compound 2; then compounds 3, 1 and 4 (each within the scatter of the next).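

In this assay, within the data shown here, the change from benzylsulfanyl to (4-fluorobenzyl)sulfanyl gives the first direct reading at this position, a number 5.1 percentage points higher from compound 3 to compound 4 (within the scatter). At this position on the benzyl ring, para to a large group, fluoro can therefore stand in place of hydrogen without a shift beyond the scatter. No measurement of any property of these compounds accompanies this result. From the compounds shown here alone, whether an amine or a carboxylic acid at this position would shift the number beyond the scatter stays open.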